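A few compounds are considered here, and "the series" means these few. Any claim that something is new, unique, unknown or untested is made for them only; others in the source may bear on it.

Measured compounds:
Compound 1, `CCN(CC)C(=O)CN(c1ccc(C)cc1)S(=O)(=O)c1ccc(OC(F)(F)F)cc1`, in a functional assay on CHO cells for inhibition of Orexin/Hypocretin receptor type 1 (Homo sapiens), read by FLIPR and calcium flux (on this read-out lower numbers stand for stronger inhibition and higher numbers for weaker inhibition), gives > 10000 nM.
Compound 2, `CCN(CC)C(=O)CN(c1cc(C(C)C)ccc1Cl)S(=O)(=O)c1ccc(OC)c(OC)c1`, gives 888 nM in this assay.

For compound 1 the value is a limit of the assay and not a number: it sits at the limit of > 10000 nM in this assay, at which 1 of the 2 values shown sits, so only this boundary is known for compound 1. Compound 2 carries a different pattern of groups on both of its aromatic rings, and no single-step comparison with compound 1 exists, so its value can only be set beside that of compound 1 without drawing any conclusion about which change matters.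

Compound 3, `CCN(CC)C(=O)CN(c1ccc(C)cc1)S(=O)(=O)c1ccc(Br)cc1`, differs from compound 1 in one place: bromo in place of trifluoromethoxy on an aromatic carbon. Within the data shown here, no measured pair of compounds shows what such a change does in this assay, so the expectation rests on compound 1 alone. Since compound 1 gives > 10000 nM, the step that the limit leaves unreadable from compound 1 to compound 3 is expected to stay within the usual scatter, with no clear direction. Compound 3 is therefore estimated at 15000 nM, with a range from 3000 nM to 60000 nM, and a real chance that only a limit is reported again.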

Compound 3, half-maximal inhibitory concentration: > 10000 nM
Compound 3: a limit, no number; the forecaster's own chance of this, stated with the estimate: 65%; the middle value lies beyond the limit too.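

In this assay compound 3 gives > 10000 nM, a limit and not a number. Among these compounds, compound 1 sits at a limit too, so no step from compound 1 to compound 3 can be read: the limit of > 10000 nM in this assay, at which 2 of the 3 values shown sit. Still open, going by these compounds, is which of the changes on the two aromatic rings sets compound 2, at 888 nM, apart.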